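Notes on benzyloxy-bearing compounds in this assay

This account rests on a few compounds, and the source may have more. Where it says the series, first, only, none or still open, it means among the compounds named here.

Measured so far:
compound 1, `Nc1nc(N)c(Br)c(OCc2ccccc2)n1`: 0.8 uM
compound 2, `Oc1nc(OCc2ccccc2)c2[nH]cnc2n1`: 35 uM
compound 3, `Oc1nc(OCc2ccccc2)c2[nH]c(O)nc2n1`: 45 uM

In an assay on HT-29 cells with Methylated-DNA--protein-cysteine methyltransferase (Homo sapiens) as the target, with a stated time of 4 h (on this read-out higher numbers stand for an effect only at larger amounts of compound and lower numbers for an effect already at smaller amounts), compound 1 gives 0.8 uM, compound 2 gives 35 uM and compound 3 gives 45 uM. Compound 2 stands second highest of the three numbers; its nearest neighbour is compound 3, and the gap a 1.3-fold higher number from compound 2 to compound 3 (0.11 log units; within the scatter) lies within the scatter. The number for compound 1, on a different core, lies far lower than that of compound 2, beyond the scatter.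

Compound 4, `CNc1nc(OCc2ccccc2)c2[nH]cnc2n1`, differs from compound 2 in one place: methylamino in place of hydroxy on an aromatic carbon. For the measured compounds named here, no measured step exchanges one group for another at this position; the only step at hand, a 1.3-fold higher number from compound 2 to compound 3 (0.11 log units; within the scatter), concerns a hydroxy added elsewhere on the core and is within the scatter. Nothing in the measured set therefore supports a firm direction. For compound 4 the step of a 2.3-fold lower number from compound 2 to compound 4 (0.37 log units; beyond the scatter) is expected, a modest move towards lower numbers that may still fall within the scatter. The estimate for compound 4 is 15 uM, with a range from 3 uM to 60 uM.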

Compound 4, concentration for half-maximal effect: 60 uM
Compound 4: the middle estimate sits 4.0-fold (0.60 log units) below what was measured; measured number inside the range.
By their numbers in this assay, from the lowest: compound 1; then compounds 2, 3 and 4 (each within the scatter of the next).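

Methylamino in place of hydroxy on the aromatic carbon between two ring nitrogen atoms gives a 1.7-fold higher number from compound 2 to compound 4 (0.23 log units; within the scatter), the only exchange of one group for another measured at this position. In this assay the two groups therefore cannot be told apart at this position, although they differ in heavy atoms and match in their counts of hydrogen-bond donors and acceptors. No measurement at hand bears on why the two groups read alike.

Open, from the compounds shown here alone, is whether a plain amine, a dimethylamino group or a longer chain such as butylamino at this position would move the number beyond the scatter. Also open is what a change to the benzyloxy group would do on the shared core, as every step shown leaves that group in place.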